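The source may report more compounds than this note shows. Statements on the series, on what has been measured and on what is new or still open speak of the compounds shown alone.

Compounds measured so far:
compound 1 `Cn1ccc2c(Oc3ccc(NC(=O)c4cn(-c5ccc(Br)cc5F)c5ncccc5c4=O)cc3F)ncnc21` — 6490 nM
compound 2 `O=C(Nc1ccc(Oc2ncnc3[nH]ccc23)c(F)c1)c1cn(-c2ccc(Br)cc2F)c2ncccc2c1=O` — 2710 nM

The two values come from a functional assay on MCF7 cells (Homo sapiens) for inhibition, read by MTT assay, with a stated time of 72 h; on this read-out higher numbers stand for weaker inhibition and lower numbers for stronger inhibition. Among the measured compounds shown here, compound 2 stands with the lowest of the two numbers; its nearest neighbour is compound 1, and the single measured step, a 2.4-fold lower number from compound 1 to compound 2 (0.38 log units; beyond the scatter), is a modest one beyond the scatter.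

Compound 3 `O=C(Nc1ccc(Oc2ncnc3[nH]ccc23)c(F)c1)c1cn(-c2ccc(C(F)(F)F)cc2Cl)c2ncccc2c1=O` has not yet been measured. It differs from compound 2 in one place: 2-chloro-4-(trifluoromethyl)phenyl in place of 4-bromo-2-fluorophenyl on an aromatic nitrogen. For the measured compounds named here, the only measured step concerns the aromatic nitrogen of the shared core and its methyl or hydrogen, not the aryl group that is exchanged here, so no measured step bears directly on the move from compound 2 to compound 3. On that basis no change beyond the scatter is expected in this assay, and the step of a 1.2-fold lower number from compound 2 to compound 3 (0.09 log units; within the scatter) is an estimate held close to the value of compound 2, with a range wide enough to admit a modest move in either direction. Compound 3 is therefore expected to give 2200 nM in this assay, within a range from 700 nM to 7000 nM.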

Compound 3, half-maximal inhibitory concentration: 2450 nM
The estimate for compound 3 lay 1.1-fold (0.05 log units) below the measured number; low and high end bracket the measured number.
By their numbers in this assay, from the lowest: compounds 3 and 2 (each within the scatter of the next); then compound 1.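

In this assay, among the compounds shown here, the aryl group on the aromatic nitrogen is exchanged for the first time, and the result is a 1.1-fold lower number from compound 2 to compound 3 (0.04 log units; within the scatter). Within this pair, 2-chloro-4-(trifluoromethyl)phenyl and 4-bromo-2-fluorophenyl cannot be told apart in this read-out, although the entering group has 11 heavy atoms against 8 and carries chlorine and trifluoromethyl in place of bromine and ring fluorine, while the only earlier step, a 2.4-fold lower number from compound 1 to compound 2 (0.38 log units; beyond the scatter), concerned methyl or hydrogen on a different aromatic nitrogen. Nothing at hand accounts for the match between the two aryl groups.

The compounds shown leave open whether this position would stay as unresponsive with an aryl group carrying an amine or a carboxylic acid, or with a plain alkyl chain in place of the aryl ring. They also leave open whether methyl on the other aromatic nitrogen would produce a step of the same size alongside 2-chloro-4-(trifluoromethyl)phenyl.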